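Adding a Nitro Group to Compound 3

The source may report more compounds than this note shows. Statements on the series, on what has been measured and on what is new or still open speak of the compounds shown alone.

Compound 1, `CC1=CC[C@H](C(C)(C)NC(=S)N/N=C/c2ccc(Cl)cc2)CC1`: 11200 nM
Compound 2, `CC1=CC[C@H](C(C)(C)NC(=S)N/N=C/c2ccc[nH]2)CC1`: 14800 nM
Compound 3, `CC1=CC[C@H](C(C)(C)NC(=S)N/N=C(\C)c2ccccc2)CC1`: > 100000 nM

In a functional assay on UACC-62 cells (Homo sapiens) for inhibition, read by sulforhodamine B assay, with a stated time of 48 h (on this read-out higher numbers stand for weaker inhibition of growth and lower numbers for stronger inhibition of growth), compound 1 gives 11200 nM and compound 2 gives 14800 nM. Among the compounds with values here, the only single-point step among the measured compounds, a 1.3-fold higher number from compound 1 to compound 2 (0.12 log units; within the scatter), is within the scatter. Compound 3 stands apart from both: in this assay compound 3 reaches only the limit of the assay, > 100000 nM, so no number is known for it. This is the case described by the limit of > 100000 nM in this assay, at which 1 of the 3 values shown sits.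

Compound 4, `CC1=CC[C@H](C(C)(C)NC(=S)N/N=C(\C)c2ccc([N+](=O)[O-])cc2)CC1`, differs from compound 3 by nitro in place of hydrogen on an aromatic carbon. Within the data shown here, no measured step adds a group to the aromatic ring of this series; the step from compound 1 to compound 2 exchanges one ring for another and bears on the change only distantly, and it was within the scatter. With compound 3 already at the limit, there is no measured number from which a shift could be read off. The expectation for compound 4 in this assay is therefore that it most likely also reaches the limit, and the estimated step of a number no higher from compound 3 to compound 4 (the limit leaves the size open) is essentially none. For compound 4 the estimate is 100000 nM, with a range from 30000 nM to 300000 nM.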

Compound 4, concentration for 50% growth inhibition: 7200 nM
Compound 4: the middle estimate sits 14-fold (1.14 log units) above what was measured, outside the stated range (below it).
By their numbers in this assay, from the lowest: compounds 4, 1 and 2 (each within the scatter of the next, the first and the last beyond it). At a limit, above all of these: compound 3.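

Within the data shown here, the nitro group on the aromatic carbon para to a large group gives the first measured change at this position in this assay, and the change is large (an at least 13-fold lower number from compound 3 to compound 4 (1.14 log units; beyond the scatter)). The only earlier step, an exchange of one ring for another, stayed within the scatter (a 1.3-fold higher number from compound 1 to compound 2 (0.12 log units; within the scatter)), so this is the first single change among the compounds shown that moves the number beyond it. Going by these compounds, compound 3 stands at a limit of the assay (> 100000 nM) and not at a number, so the step fixes only a smallest size for the change, and its full size remains unknown: the limit of > 100000 nM in this assay, at which 1 of the 4 values shown sits.

The compounds shown do not tell whether this shift belongs to nitro alone, or whether an amine, a nitrile or a carboxylic acid on the same aromatic carbon would move the number as well. They also leave open whether nitro has a similar effect on a compound that lacks the methyl on the carbon with a double bond to nitrogen, as compound 1 and compound 2 do.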